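Replacing a Hydroxy with a Dimethylamino Chain

The source may report more compounds than this note shows. Statements on the series, on what has been measured and on what is new or still open speak of the compounds shown alone.

Compound 1 `Cn1c(N)c(-c2nc3ccccc3[nH]2)c2nc(C#N)c(C#N)nc21` gives > 50000 nM in a functional assay on HL-60 cells (Homo sapiens) for antiproliferative activity, read by MTT assay, with a stated time of 48 h (on this read-out higher numbers stand for weaker inhibition and lower numbers for stronger inhibition), a limit of the assay rather than a number.
Compound 2 `N#Cc1nc2c(-c3nc4ccccc4[nH]3)c(N)n(CCO)c2nc1C#N` gives > 50000 nM in this assay, again only a limit.
Compound 3 `CCN(CC)CCCCn1c(N)c(-c2nc3ccccc3[nH]2)c2nc(C#N)c(C#N)nc21` gives 460 nM in this assay.

Compound 2 therefore stands at the limit (the limit of > 50000 nM in this assay, at which 2 of the 3 values shown sit), with no measured number of its own. The not yet measured compound 4 `CN(C)CCCCCn1c(N)c(-c2nc3ccccc3[nH]2)c2nc(C#N)c(C#N)nc21` differs from it in one place: 3-(dimethylamino)propyl in place of hydroxy on a saturated chain carbon, two bonds along the chain from an aromatic nitrogen.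

Among the compounds with values here, one measured step bears directly on this change. It is an at least 100-fold lower number from compound 2 to compound 3 (2.03 log units; beyond the scatter), where a diethylamino-bearing chain replaced the hydroxy at the same position. The related step of an at least 100-fold lower number from compound 1 to compound 3 (2.03 log units; beyond the scatter), in which a diethylamino-bearing chain replaced hydrogen, points the same way. Both were large and beyond the scatter. The change from compound 2 to compound 4 brings a dimethylamino-bearing chain of similar kind to the same position, so a large drop of comparable size is expected in this assay, toward stronger inhibition.

Compound 4 is accordingly expected to give about 700 nM, with a range from 200 nM to 3000 nM. The step this estimate implies is an at least 71-fold lower number from compound 2 to compound 4 (1.85 log units; beyond the scatter).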

Compound 4, half-maximal inhibitory concentration: 3420 nM
Compound 4: the middle estimate sits 4.9-fold (0.69 log units) below what was measured; measured number outside the range, above it.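

The gain in this assay does not belong to the diethylamino group alone, for a second amine-bearing chain at this position also moves the read-out far toward stronger inhibition, whether it is compared with the hydroxy chain (an at least 14-fold lower number from compound 2 to compound 4 (1.16 log units; beyond the scatter)) or with the methyl of compound 1 (an at least 14-fold lower number from compound 1 to compound 4 (1.16 log units; beyond the scatter)). The two amine-bearing chains are still not interchangeable, and the difference between them is modest but beyond the scatter (a 7.4-fold higher number from compound 3 to compound 4 (0.87 log units; beyond the scatter)). Both large steps give only a minimum size, because neither compound 1 nor compound 2 has a measured number of its own: (the limit of > 50000 nM in this assay, at which 2 of the 4 values shown sit).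

The step between compound 3 and compound 4 alters the groups on the amine and the length of the chain together, so the compounds shown cannot say how much of it comes from each. Also open, going by these compounds, is whether a pentyl chain ending in diethylamino, a shorter chain ending in dimethylamino, or a chain ending in a ring amine such as piperidine would give a lower or a higher number in this assay.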